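Deoxyuridine 5-substituent swap: oxime to hydroxypentynyl

This account rests on a few compounds, and the source may have more. Where it says the series, first, only, none or still open, it means among the compounds named here.

Compound 1, `O=c1[nH]c(=O)n([C@H]2C[C@H](O)[C@@H](CO)O2)cc1/C=N/O`: 15500 nM
Compound 2, `CC1=C(C)C(=O)C(c2cn([C@H]3C[C@H](O)[C@@H](CO)O3)c(=O)[nH]c2=O)=CC1=O`: 112000 nM
Compound 3, `O=C1O/C(=C\Cn2ccc(=O)[nH]c2=O)C(Cc2ccccc2)=C1O`: > 200000 nM

In an ADME assay on L1210/0 cells (Mus musculus) for cytotoxicity, with a stated time of 48 h (on this read-out higher numbers stand for weaker inhibition and lower numbers for stronger inhibition), compound 1 gives 15500 nM, the lowest of the two numbers recorded, with compound 2 standing higher at 112000 nM beyond the scatter. Compound 3 reaches only a limit, > 200000 nM, and so gives no number.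

Compound 4, `O=c1[nH]c(=O)n([C@H]2C[C@H](O)[C@@H](CO)O2)cc1C#CCCCO`, differs from compound 1 by a group of 6 heavy atoms (5 carbon, 1 oxygen; no ring) in place of a group of 3 heavy atoms (1 carbon, 1 nitrogen, 1 oxygen; no ring), on an aromatic carbon, a 5-hydroxypent-1-yn-1-yl group replacing the oxime-bearing group on the shared core. Among the compounds with values here, no measured step guides this change, so the expected step from compound 1 to compound 4 in this assay is a modest weakening, a 3.9-fold higher number from compound 1 to compound 4 (0.59 log units; beyond the scatter), with a chance that compound 4 ends at the limit. Compound 4 is therefore estimated at 60000 nM, within 10000 nM to 300000 nM.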

Compound 4, half-maximal inhibitory concentration: > 200000 nM
Compound 4 gave a limit, no number; the forecaster's own chance of this, stated with the estimate: 30%; middle value at least 3.3-fold (0.52 log units) from the limit.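

Swapping the oxime-bearing group for 5-hydroxypent-1-yn-1-yl on this aromatic carbon gives an at least 12-fold higher number from compound 1 to compound 4 (1.11 log units; beyond the scatter) in this assay. Within the data shown here, this is the first comparison at this position in which only one group changes, and it shows that the read-out depends strongly on the group placed there. Compound 4 carries a limit and not a number, so the full size of the step stays unknown: the limit of > 200000 nM in this assay, at which 2 of the 4 values shown sit.

The compounds shown leave open whether the triple bond or the hydroxyl of the new chain matters more. They also leave open how a shorter chain, or an amine or carboxylic acid at the chain end, would read.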